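Expected cytotoxicity of compound 4 after a phenyl-to-phenethyl swap

This account rests on a few compounds, and the source may have more. Where it says the series, first, only, none or still open, it means among the compounds named here.

Compound 2 `Cc1nc(C)c([C@H](OC(C)(C)C)C(=O)O)c(N2CCC(C)(C)CC2)c1-c1ccc(Oc2ccccc2)cc1` stands at a limit rather than at a number: in a toxicity assay on MT2 cells (Homo sapiens) for cytotoxicity, read by XTT assay, with a stated time of 4 days (on this read-out higher numbers stand for lower toxicity in this test and lower numbers for higher toxicity in this test), compound 2 gives >= 20000 nM, which is a limit of the assay. Compound 1 `Cc1nc(C)c([C@H](OC(C)(C)C)C(=O)O)c(N2CCC(C)(C)CC2)c1-c1ccc(-c2ccccc2)cc1` likewise reaches only a limit, giving >= 20000 nM in this assay. Compound 3 `Cc1nc(C)c([C@H](OC(C)(C)C)C(=O)O)c(N2CCC(C)(C)CC2)c1-c1ccc(OCCc2ccc(C#N)cc2)cc1` is the same case, giving >= 33500 nM in this assay, again a limit. The step most relevant here is a step that the two limits leave unreadable from compound 2 to compound 3; the neighbouring steps a step that the two limits leave unreadable from compound 1 to compound 2 and a step that the two limits leave unreadable from compound 1 to compound 3 are equally unreadable, and the limit of >= 20000 nM in this assay, at which 2 of the 3 values shown sit, together with the limit of >= 33500 nM in this assay, at which 1 of the 3 values shown sits, is all the values reveal. Compound 4 `Cc1nc(C)c([C@H](OC(C)(C)C)C(=O)O)c(N2CCC(C)(C)CC2)c1-c1ccc(OCCc2ccc(F)cc2F)cc1` differs from compound 2 by 2-(2,4-difluorophenyl)ethyl in place of phenyl on an oxygen on an aromatic ring. With no readable step to lean on, no change beyond the scatter is expected, and the estimated step from compound 2 to compound 4 is a step that the limit leaves unreadable from compound 2 to compound 4. Compound 4 is therefore expected to give about 25000 nM, within 12000 nM to 60000 nM, most probably reported again only as a limit.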

Compound 4, half-maximal cytotoxic concentration: >= 33500 nM
Compound 4 ended at the assay's limit (the forecaster's own chance of this, stated with the estimate: 80%); middle value at least 1.3-fold (0.12 log units) from the limit.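

Among the compounds shown here, compound 4 reaches only a limit, as do compounds 1, 2 and 3, and no step between any of them can be read. The compounds shown leave open at what concentration each becomes toxic, and whether these group swaps change it.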